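Urea to benzamide: one change in a shared core

This account rests on a few compounds, and the source may have more. Where it says the series, first, only, none or still open, it means among the compounds named here.

Measured compounds: compound 1 `O=C(Nc1cccc(-n2cc(-c3ccncc3)c(-c3ccc(Cl)c(O)c3)n2)c1)Nc1ccc(Cl)c(Cl)c1` gives 1230 nM; compound 2 `COc1cc(-c2nn(-c3cccc(NC(=O)c4ccc(Cl)c(C(F)(F)F)c4)c3)cc2-c2ccncc2)ccc1Cl` gives 3250 nM; compound 3 `COc1cc(-c2nn(-c3cccc(NC(=O)Nc4cccc(C(F)(F)F)c4)c3)cc2-c2ccncc2)ccc1Cl` gives 870 nM, all in a functional assay on HCT-15 cells (Homo sapiens) for inhibition, read by sulforhodamine B assay, with a stated time of 48 h; on this read-out lower numbers stand for stronger inhibition of growth and higher numbers for weaker inhibition of growth.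

Compound 3 has the lowest of the three numbers, though compound 1 sits within the scatter of it, while compound 2 lies beyond it. Compound 4 `COc1cc(-c2nn(-c3cccc(NC(=O)c4ccccc4)c3)cc2-c2ccncc2)ccc1Cl` differs from compound 3 by phenyl in place of (3-(trifluoromethyl)phenyl)amino on a carbonyl carbon. Among the compounds with values here, the only measured step touching this position is a 3.7-fold lower number from compound 2 to compound 3 (0.57 log units; beyond the scatter), where the urea gave the lower number than the amide. Compound 4 returns to an amide, but one without chlorine or trifluoromethyl, so compound 2 is only a rough guide. Compound 4 is therefore expected to show a higher number than compound 3, with a 4.0-fold higher number from compound 3 to compound 4 (0.60 log units; beyond the scatter), and its estimated value in this assay is 3500 nM (range 1200 nM to 10000 nM).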

Compound 4, concentration for 50% growth inhibition: 654 nM
Beside the measured number, compound 4's estimate is 5.4-fold (0.73 log units) above it; the whole stated range lies above it.
By their numbers in this assay, from the lowest: compounds 4, 3 and 1 (each within the scatter of the next); then compound 2.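

In this assay, phenyl on the carbonyl carbon gives a 1.3-fold lower number from compound 3 to compound 4 (0.12 log units; within the scatter), so at this position neither the amino link of the urea nor the trifluoromethyl group is required for a number in this range. Within the amides, removing the substituted ring's chlorine and trifluoromethyl gives a 5.0-fold lower number from compound 2 to compound 4 (0.70 log units; beyond the scatter), which shows that an amide as such does not carry the higher number of compound 2. Nothing available explains either step.

The compounds shown leave open whether chlorine or trifluoromethyl alone accounts for that step. They also leave open how a carboxylic acid or a dimethylamino group on this phenyl ring would read.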